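A few compounds are considered here, and "the series" means these few. Any claim that something is new, unique, unknown or untested is made for them only; others in the source may bear on it.

In a functional assay on ACHN cells (Homo sapiens) for antiproliferative activity, read by sulforhodamine B assay (a lower number here means a stronger inhibitor of growth, a higher number a weaker inhibitor of growth), compound 1 `CC(C)CCCOc1cccc(O)c1C(=O)/C=C/c1ccc(O)cc1` gives 3630 nM. Compound 2 `O=C(/C=C/c1ccc(O)cc1)c1c(O)cccc1OCC1CCCCC1` gives only a limit, > 30000 nM. Compound 3 `CC(C)COc1cccc(O)c1C(=O)/C=C/c1ccc(O)cc1` keeps the shared core but has isopropyl in place of cyclohexyl on a saturated chain carbon bound to an oxygen on an aromatic ring. Among the compounds with values here, one measured step bears on this change: with cyclohexyl in place of isopentyl at that place, the number rose in an at least 8.2-fold higher number from compound 1 to compound 2 (0.91 log units; beyond the scatter). Removing the ring again is therefore expected to bring a clear move towards a lower number, an at least 3.7-fold lower number from compound 2 to compound 3 (0.57 log units; beyond the scatter). Compound 3 is estimated at 8000 nM, with an expected range of 2500 nM to 28000 nM.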

Compound 3, concentration for 50% growth inhibition: 3290 nM
Compound 3: middle estimate off by 2.4-fold (0.39 log units), on the high side; low and high end bracket the measured number.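

Swapping isopentyl for isopropyl gives a 1.1-fold lower number from compound 1 to compound 3 (0.04 log units; within the scatter), so these two open chains cannot be told apart at this position. Swapping cyclohexyl for isopropyl gives an at least 9.1-fold lower number from compound 2 to compound 3 (0.95 log units; beyond the scatter), so among these compounds the weak result goes with the cyclohexyl ring, not with an open chain. Compound 2 is known only as a limit: the limit of > 30000 nM in this assay, at which 1 of the 3 values shown sits.

On these data alone, the true size of the loss with the cyclohexyl ring therefore stays open. So does whether a smaller ring such as cyclopropyl, a longer chain or an amine would keep the growth inhibition at this place.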